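Swapping the Halogens on the Aniline Ring of Compound 1

The source may report more compounds than this note shows. Statements on the series, on what has been measured and on what is new or still open speak of the compounds shown alone.

Compound 1 `Cc1cc(Nc2cc(N3CCN(C)CC3)nc(Nc3ccc(F)c(F)c3)n2)n[nH]1` is the reference point of this small set. In a functional assay on K562 cells (Homo sapiens) for antiproliferative activity, read by CCK-8 assay, with a stated time of 48 h (a higher number here means a weaker inhibitor, a lower number a stronger inhibitor), compound 1 gives 195 nM, the lowest number among the three measured compounds. Compound 2 `Cc1cc(Nc2cc(N3CCN(C)CC3)nc(Nc3ccc(F)cc3)n2)n[nH]1` gives 357 nM, and compound 3 `COc1ccc(Nc2nc(Nc3cc(C)[nH]n3)cc(N3CCN(C)CC3)n2)cc1OC` gives 462 nM.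

Both measured steps away from compound 1 alter the same aryl group. Hydrogen in place of fluoro on an aromatic carbon gives a 1.8-fold higher number from compound 1 to compound 2 (0.26 log units; within the scatter). Exchanging that whole aryl group for a differently substituted one gives a 2.4-fold higher number from compound 1 to compound 3 (0.37 log units; beyond the scatter). Between the two altered compounds, a 1.3-fold higher number from compound 2 to compound 3 (0.11 log units; within the scatter).

Compound 4 `Cc1cc(Nc2cc(N3CCN(C)CC3)nc(Nc3ccc(Cl)c(Cl)c3)n2)n[nH]1` differs from compound 1 by 3,4-dichlorophenyl in place of 3,4-difluorophenyl on a nitrogen on an aromatic ring. Among the measured compounds shown here, no measured pair exchanges one halogen for another, so the two steps from compound 1 are the only guides, and both moved the number upward only a little. Because a 1.8-fold higher number from compound 1 to compound 2 (0.26 log units; within the scatter) stayed within the scatter and a 2.4-fold higher number from compound 1 to compound 3 (0.37 log units; beyond the scatter) was merely modest, the change to compound 4 is expected to leave the number close to that of compound 1, with no step beyond the scatter in either direction. This amounts to an expected step of a 1.1-fold higher number from compound 1 to compound 4 (0.05 log units; within the scatter). Compound 4 is therefore estimated at about 220 nM, most likely between 80 nM and 600 nM.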

Compound 4, half-maximal inhibitory concentration: 128 nM
Beside the measured number, compound 4's estimate is 1.7-fold (0.24 log units) above it; measured number inside the range.
By their numbers in this assay, from the lowest: compounds 4, 1, 2 and 3 (each within the scatter of the next, the first and the last beyond it).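

In this assay, the exchange of fluorine for chlorine on this aryl group, which sits on a nitrogen on an aromatic ring, gives a 1.5-fold lower number from compound 1 to compound 4 (0.18 log units; within the scatter), so the 3,4-dichlorophenyl and 3,4-difluorophenyl compounds cannot be told apart here. The larger contrasts appear against the other two aryl groups: 3,4-dichlorophenyl in place of 3,4-dimethoxyphenyl gives a 3.6-fold lower number from compound 3 to compound 4 (0.56 log units; beyond the scatter), and 3,4-dichlorophenyl in place of 4-fluorophenyl gives a 2.8-fold lower number from compound 2 to compound 4 (0.45 log units; beyond the scatter). The second of these steps is new information, since compound 2 had stayed within the scatter of compound 1, and it shows that a compound with two halogens on this ring can separate clearly from one with a single halogen, although compound 1, also with two halogens, does not.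

Going by these compounds, whether a single chlorine, as in 4-chlorophenyl, or a 3,4-dibromophenyl or 4-(trifluoromethyl)phenyl group at this place would keep the number as low as in compound 4 remains open. The results shown also include no measurement that explains why these aryl groups give different numbers.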